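Ethyl for methyl on a sulfonamide: cytotoxicity readings

The source may report more compounds than this note shows. Statements on the series, on what has been measured and on what is new or still open speak of the compounds shown alone.

Measured compounds:
compound 1, `Cc1cc(NC(=O)c2ccc(Cl)c([N+](=O)[O-])c2)ccc1NS(C)(=O)=O`, 73100 nM
compound 2, `CCS(=O)(=O)Nc1ccc(NC(=O)c2ccc(Cl)c([N+](=O)[O-])c2)cc1C`, 144000 nM
compound 3, `CS(=O)(=O)Nc1ccc(NC(=O)c2cccc(C(F)(F)F)c2)cc1Cl`, > 250000 nM

The three measured compounds and the unmeasured compound 4, `CCS(=O)(=O)Nc1ccc(NC(=O)c2cccc(C(F)(F)F)c2)cc1Cl`, were examined in an ADME assay on HEK293 cells (Homo sapiens) for cytotoxicity, read by MTT assay, with a stated time of 48 h; a higher number here means a weaker inhibitor, a lower number a stronger inhibitor. In this assay compound 1 gives 73100 nM, and compound 2 gives 144000 nM. The change between them is methyl in place of hydrogen on a saturated chain carbon bound to a sulfonyl sulfur, and it produced a 2.0-fold higher number from compound 1 to compound 2 (0.29 log units; within the scatter). Compound 3 gives > 250000 nM, which is a limit of this assay and not a number; it sits at the limit of > 250000 nM in this assay, at which 1 of the 3 values shown sits. The difference between the core of compound 1 and the core of compound 3 is not broken down here.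

Compound 4 differs from compound 3 by methyl in place of hydrogen on a saturated chain carbon bound to a sulfonyl sulfur, the same change as that from compound 1 to compound 2, and it occurs twice among these compounds. Since the earlier step of a 2.0-fold higher number from compound 1 to compound 2 (0.29 log units; within the scatter) stayed within the scatter, the corresponding step is expected to be small as well, and the value for compound 4 is estimated to lie at or beyond the limit of this assay, as compound 3 did. The step that this estimate means is a step that the limit leaves unreadable from compound 3 to compound 4, and it is expected on the strength of the measured step of a 2.0-fold higher number from compound 1 to compound 2 (0.29 log units; within the scatter). Compound 4 is therefore expected to give about 350000 nM, with an estimated range from 150000 nM to 800000 nM.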

Compound 4, half-maximal inhibitory concentration: 159000 nM
Compound 4: middle estimate off by 2.2-fold (0.34 log units), on the high side, and the stated range covers the measured number.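

Placed on the core of compound 3, methyl in place of hydrogen on the saturated chain carbon bound to the sulfonyl sulfur gives, in this assay, an at least 1.5-fold lower number from compound 3 to compound 4 (0.19 log units; that floor lies within the scatter). Compound 3 gives > 250000 nM, which is a limit of this assay and not a number. Set beside the step on the core of compound 1, this result shows that the change does not carry from one core to the other as a fixed shift, although it does not show how large the step on the core of compound 3 really is or what sets the two steps apart, and a single pair on each core supports no rule for the series: the same change on two cores in this assay, a 2.0-fold higher number (0.29 log units; within the scatter) from compound 1 to compound 2 and an at least 1.5-fold lower number (0.19 log units; that floor lies within the scatter) from compound 3 to compound 4, at least 3.0-fold (0.49 log units) apart, beyond the scatter of two such steps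

The core of compound 1 and the core of compound 3 differ in more than one place, so the compounds shown leave open which of those differences goes with the gap between the two steps. They also leave open how a longer chain such as propyl or butyl, or a cyclopropyl group, on the sulfonyl sulfur would read on either core, and whether the same change on further cores would follow the step from the core of compound 1 or the step from the core of compound 3.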